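Chloro on the anilino ring of the shared core

The compounds below may be only part of what the source reports. "The series", "measured", "known", "first", "only" and "open" are said of these compounds alone.

Measured so far in a functional assay on the whole organism (strain albino) for inhibition, with Rattus norvegicus as the target, read by paw edema, with a stated time of 1 h, at a dose of 100 mg/kg by the oral route; on this read-out lower numbers stand for less inhibition and higher numbers for more inhibition at the one dose given (going by the name of the read-out):
compound 1 `N#Cc1c(Cl)nc(SCC(=O)Nn2c(COc3ccc(Cl)cc3Cl)nc3ccccc3c2=O)nc1-c1ccc(O)cc1`: 72.7%
compound 2 `N#Cc1c(Nc2ccc(Cl)cc2)nc(SCC(=O)Nn2c(COc3ccc(Cl)cc3Cl)nc3ccccc3c2=O)nc1-c1ccccc1`: 54.6%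
compound 3 `N#Cc1c(Nc2ccccc2)nc(SCC(=O)Nn2c(COc3ccc(Cl)cc3Cl)nc3ccccc3c2=O)nc1-c1ccc(O)cc1`: 90.9%

Compound 3 gives the highest of the three numbers in this assay, ahead of compound 1 and further ahead of compound 2. Among the compounds with values here, the one step recorded within the set is a number 18.2 percentage points higher from compound 1 to compound 3 (beyond the scatter), a modest gain beyond the scatter. Compound 4 `N#Cc1c(Nc2ccc(Cl)cc2)nc(SCC(=O)Nn2c(COc3ccc(Cl)cc3Cl)nc3ccccc3c2=O)nc1-c1ccc(O)cc1` carries the change (chloro in place of hydrogen on an aromatic carbon). Within the data shown here, no measured step covers this change directly; compound 2, which bears the same (4-chlorophenyl)amino group but a phenyl without hydroxyl, gives 54.6%, while compound 3 gives 90.9%. For compound 4 a number somewhat below compound 3 is expected, a number 12.9 percentage points lower from compound 3 to compound 4 (beyond the scatter). Compound 4 is estimated at 78%, between 58% and 95%.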

Compound 4, a percentage reported as inhibition, in the whole organism at one dose (the size of the read-out at that dose, not a potency): 72.7%
The estimate for compound 4 lay 5.3 percentage points above the measured number; the measured number falls inside the stated range.
By their numbers in this assay, from the lowest: compound 2; then compounds 1 and 4 (each within the scatter of the next); then compound 3.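

Chloro in place of hydrogen on the anilino ring gives a number 18.2 percentage points lower from compound 3 to compound 4 (beyond the scatter) in this assay and so shows that this ring position is not indifferent to substitution. With (4-chlorophenyl)amino held constant, hydroxy in place of hydrogen gives a number 18.1 percentage points higher from compound 2 to compound 4 (beyond the scatter) and, against the chloro of compound 1, (4-chlorophenyl)amino gives no change at the digits printed from compound 1 to compound 4 (within the scatter) in the same assay, so the advantage of anilino over chloro is not retained once the ring carries chloro. Nothing available explains these steps.

Open, going by these compounds, is whether fluoro, methyl or methoxy at this place would behave as chloro does. Also open, on these data alone, is how a dimethylamino group or a morpholine ring would compare with anilino on the shared core.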